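Adding a methoxy to the dimethoxyphenyl ketone of compound 2

The compounds below may be only part of what the source reports. "The series", "measured", "known", "first", "only" and "open" are said of these compounds alone.

Compound 1: `COc1cc(-c2cc(/C=C/C(=O)c3ccc(N)cc3)[nH]n2)cc(OC)c1OC`, 51600 nM
Compound 2: `COc1ccc(C(=O)/C=C/c2cc(-c3cc(OC)c(OC)c(OC)c3)n[nH]2)cc1OC`, 5100 nM
Compound 3: `COc1ccc(C(=O)/C=C/c2cc(-c3cc(OC)c(OC)c(OC)c3)n[nH]2)cc1`, a limit, > 100000 nM

Of the compounds shown here, three have been measured in a functional assay on TK-10 cells (Homo sapiens) for inhibition, read by sulforhodamine B assay, with a stated time of 48 h; a lower number here means that less compound is tolerated, a higher number that more compound is tolerated. Compound 2 holds the lowest of the two numbers; compound 1 stands nearest, and the step of a 10-fold lower number from compound 1 to compound 2 (1.01 log units; beyond the scatter) is large. Compound 3 gives only a limit in this assay, (the limit of > 100000 nM in this assay, at which 1 of the 3 values shown sits).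

Compound 4, `COc1cc(C(=O)/C=C/c2cc(-c3cc(OC)c(OC)c(OC)c3)n[nH]2)cc(OC)c1OC`, has not been measured. It differs from compound 2 in one place: methoxy in place of hydrogen on an aromatic carbon.

The step that bears most directly on this change is an at least 19-fold higher number from compound 2 to compound 3 (1.29 log units; beyond the scatter), where the reverse change, the loss of a methoxy from the same ring, moved the number far upward to the limit. The other measured step, an at least 1.9-fold higher number from compound 1 to compound 3 (0.28 log units; that floor lies within the scatter), concerns a different group on that ring and says little here. Among the compounds with values here, since compound 2 already carries two methoxy groups and the third enters on the same ring, the record gives no measured step of exactly this kind, and the direction cannot be read off with confidence.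

Compound 4 is therefore expected to stay close to compound 2, with a wide range: 4000 nM, between 800 nM and 25000 nM, which would mean a step of a 1.3-fold lower number from compound 2 to compound 4 (0.11 log units; within the scatter).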

Compound 4, concentration lethal to 50% of the cells: 5340 nM
Compound 4: middle estimate off by 1.3-fold (0.13 log units), on the low side; the range from low to high includes it.
By their numbers in this assay, from the lowest: compounds 2 and 4 (each within the scatter of the next); then compound 1. At a limit, above all of these: compound 3.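

In this assay, the step of a 1.0-fold higher number from compound 2 to compound 4 (0.02 log units; within the scatter) shows that methoxy in place of hydrogen, on an aromatic carbon ortho to a methoxy group and meta to a large group, does not move the number beyond the scatter. The earlier compounds shown here showed only the loss of a methoxy from this ring, and that step, an at least 19-fold higher number from compound 2 to compound 3 (1.29 log units; beyond the scatter), is large, so the two methoxy changes on this ring do not mirror each other in size. That large step ends at compound 3, which gives only a limit and so fixes no exact size for it: the limit of > 100000 nM in this assay, at which 1 of the 4 values shown sits.

What the compounds shown leave open is whether the tolerance of this aromatic carbon extends beyond methoxy, since a hydroxy group, a chlorine atom, an amine or a longer ethoxy chain placed there could read quite differently. They also leave open whether the same reading would hold on another cell line, as all of these numbers come from this assay alone and rest on a single change at this place.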